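This account rests on a few compounds, and the source may have more. Where it says the series, first, only, none or still open, it means among the compounds named here.

Measured compounds:
- compound 1, `COc1ccc(S(=O)(=O)c2nc3ccccc3nc2N2CCc3ccccc3C2)cc1` — > 50000 nM
- compound 2, `O=S(=O)(c1ccc(Br)cc1)c1nc2ccccc2nc1N1CCc2ccccc2C1` — > 50000 nM
- compound 3, `COc1ccc(S(=O)(=O)c2nc3ccccc3nc2N2CCCC(O)C2)cc1` — 2180 nM

Compound 1 and compound 2 share a core and differ only in the group para to the sulfone, the change being (bromo in place of methoxy on an aromatic carbon). In a functional assay on A549 cells (Homo sapiens) for cytotoxicity, read by MTT assay, with a stated time of 72 h (on this read-out higher numbers stand for weaker inhibition and lower numbers for stronger inhibition), compound 1 reaches only a limit of the assay, > 50000 nM. Compound 2 likewise gives only a limit in this assay, > 50000 nM. The step between them is therefore a step that the two limits leave unreadable from compound 1 to compound 2; both values sit at the limit of > 50000 nM in this assay, at which 2 of the 3 values shown sit, and nothing about the direction or size of this change can be read from the pair.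

Compound 3 carries a different amine on the shared core: 3-hydroxypiperidin-1-yl in place of 1,2,3,4-tetrahydroisoquinolin-2-yl on an aromatic carbon. In this assay, among the compounds with values here, compound 3 gives 2180 nM, the only plain number in the set. The step is an at least 22-fold lower number from compound 1 to compound 3 (1.36 log units; beyond the scatter).

Compound 4, `O=S(=O)(c1ccc(Br)cc1)c1nc2ccccc2nc1N1CCCC(O)C1`, has not yet been measured in this assay. It relates to compound 3 exactly as compound 2 relates to compound 1: bromo in place of methoxy on an aromatic carbon. The place lines of the two changes read the same word for word, so it is the same change made on the core of compound 3 rather than the core of compound 1. The earlier occurrence gives no readable size, so the expectation for compound 4 rests mainly on the value of compound 3, 2180 nM, with a step from compound 3 to compound 4 estimated as a 1.4-fold higher number from compound 3 to compound 4 (0.14 log units; within the scatter). Compound 4 is expected to give about 3000 nM in this assay, within an estimated range from 900 nM to 12000 nM.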

Compound 4, half-maximal inhibitory concentration: 2100 nM
Estimate against measurement, compound 4: 1.4-fold (0.15 log units) above; measured number inside the range.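

Bromo in place of methoxy on the core of compound 3 gives a 1.0-fold lower number from compound 3 to compound 4 (0.02 log units; within the scatter), so on this core the change separates the two groups by nothing beyond the scatter in this assay, whereas the same change on the core of compound 1 cannot be read, since compound 1 and compound 2 both stand at a limit. The result therefore shows the change on one core only and does not show that it carries to a second one. The amine change can be followed with either group in place, with 3-hydroxypiperidin-1-yl in place of 1,2,3,4-tetrahydroisoquinolin-2-yl giving an at least 23-fold lower number from compound 2 to compound 4 (1.37 log units; beyond the scatter), and the two occurrences run the same way, both beyond the scatter, though neither has a fixed size: the same change on two cores in this assay, an at least 22-fold lower number (1.36 log units; beyond the scatter) from compound 1 to compound 3 and an at least 23-fold lower number (1.37 log units; beyond the scatter) from compound 2 to compound 4; the limit leaves it open whether they differ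

The compounds shown leave open whether the hydroxy group itself is needed on the amine, a question that an unsubstituted piperidin-1-yl or a morpholin-4-yl on the shared core would address. They also leave open how far the aromatic group can vary with 3-hydroxypiperidin-1-yl in place, for instance with a nitrile or a carboxylic acid where methoxy and bromo sit in compound 3 and compound 4.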